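The source may hold more compounds than are shown below. What is called first, only, known or untested is meant among the compounds shown, and "the series" means these compounds.

In an ADME assay (liver) for metabolic stability, with Liver microsome (Rattus norvegicus) as the target, using microsomes and NADPH, with a stated time of 30 min, at 37 degrees C, tested at 1 uM (a higher number here means faster removal of the compound, a lower number slower removal), compound 1 `CC(C)Nc1nc(S(=O)(=O)c2ccc(N)nc2)ccc1-c1ccc(C(C)(O)C(F)(F)F)cn1` gives 62 mL.min-1.g-1 and compound 2 `CC(O)(c1ccc(-c2ccc(S(=O)(=O)c3ccc(N)nc3)nc2NC2CC2)nc1)C(F)(F)F` gives 43 mL.min-1.g-1. Going by the values given here, the one measured step, a 1.4-fold lower number from compound 1 to compound 2 (0.16 log units; within the scatter), is cyclopropyl in place of isopropyl on a nitrogen on an aromatic ring.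

Compound 3 `CC(O)(c1cnc(-c2ccc(S(=O)(=O)c3ccc(N)nc3)s2)c(Cl)c1)C(F)(F)F` gives < 14 mL.min-1.g-1, which is a limit of the assay and not a number. That reading is the limit of < 14 mL.min-1.g-1 in this assay, at which 1 of the 3 values shown sits.

Compound 4 `CC#Cc1cc(C(C)(O)C(F)(F)F)cnc1-c1ccc(S(=O)(=O)c2ccc(N)nc2)s1` differs from compound 3 by one change: prop-1-yn-1-yl in place of chloro on an aromatic carbon. In short, prop-1-yn-1-yl stands in place of chloro on an aromatic carbon. Among the compounds with values here, no measured step covers this place or this pair of groups. The step of a 1.4-fold lower number from compound 1 to compound 2 (0.16 log units; within the scatter) concerns a different substituent, so it gives only a weak guide to size, and it suggests no large effect from a single substituent swap. The starting point is also only a limit, so the true size of the step cannot be fixed. A modest rise in this assay is expected, with a real chance that compound 4 also reads as a limit.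

The expected change is an at least 1.2-fold higher number from compound 3 to compound 4 (0.10 log units; that floor lies within the scatter), an estimate measured against a limit and not against a number.

For compound 4 the estimated value is 18 mL.min-1.g-1, with an expected range from 10 mL.min-1.g-1 to 40 mL.min-1.g-1.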

Compound 4, intrinsic clearance in microsomes: > 399 mL.min-1.g-1
Compound 4: only a limit was reported; the forecaster's own chance of this, stated with the estimate: 40%; middle value at least 22-fold (1.34 log units) from the limit.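

In this assay, prop-1-yn-1-yl in place of chloro on an aromatic carbon ortho to a large group gives an at least 28-fold higher number from compound 3 to compound 4 (1.45 log units; beyond the scatter), so a single swap at this place moves the read-out much further than the earlier step on the nitrogen, a 1.4-fold lower number from compound 1 to compound 2 (0.16 log units; within the scatter). Compound 3 stands at a limit of the assay and not at a number: the limit of < 14 mL.min-1.g-1 in this assay, at which 1 of the 4 values shown sits. Compound 4 also stands at a limit of the assay, at the opposite end of the shown values: the limit of > 399 mL.min-1.g-1 in this assay, at which 1 of the 4 values shown sits.

The compounds shown do not settle whether the rise follows from the triple bond or from the three-carbon chain, and a nitrile or an ethyl group at this same place would help separate the two. Nor do they show how far the true values of compound 3 and compound 4 lie beyond their limits, or whether the same swap has a step of similar size on the core of compound 1.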